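This account rests on a few compounds, and the source may have more. Where it says the series, first, only, none or still open, it means among the compounds named here.

Measured compounds in a functional assay on MCF7 cells (Homo sapiens) for antiproliferative activity; a lower number here means a stronger inhibitor, a higher number a weaker inhibitor:
- compound 1 `CC(=O)Oc1ccc(C(=O)Nc2cc3ccc(OCC4CCCNC4)c(C)c3oc2=O)cc1CC=C(C)C` gives 820 nM
- compound 2 `CC(C)=CCc1cc(C(=O)Nc2cc3ccc(OCCCN4CCCC4)c(C)c3oc2=O)ccc1O` gives 990 nM
- compound 3 `CC(C)=CCc1cc(C(=O)Nc2cc3ccc(OCCCNCC(C)C)c(C)c3oc2=O)ccc1O` gives 1320 nM

The three values fall within the scatter of one another, so compound 3 stands among them without distinction. Within the data shown here, its difference from compound 2 is the only change of a single place on record: a 1.3-fold higher number from compound 2 to compound 3 (0.12 log units; within the scatter). Compound 4 `CC(C)=CCc1cc(C(=O)Nc2cc3ccc(OCCCNc4ccccc4)c(C)c3oc2=O)ccc1O` is the next compound in this series and has not yet been measured in this assay. It differs from compound 3 in one place, (phenyl in place of isobutyl on an amine nitrogen). Among the measured compounds shown here, the one step that bears on this change is the exchange at the same amine nitrogen going from compound 2 to compound 3, which stayed within the scatter; there is no step in which a phenyl enters at such a position. On that basis a step of no more than the scatter is expected from compound 3 to compound 4, a 1.1-fold higher number from compound 3 to compound 4 (0.06 log units; within the scatter). Compound 4 is therefore estimated at 1500 nM, with a range of 600 nM to 3800 nM.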

Compound 4, half-maximal inhibitory concentration: > 50000 nM
Compound 4 was reported as a limit; the forecaster's own chance of this, stated with the estimate: 5%; at least 33-fold (1.52 log units) between middle value and limit.
By their numbers in this assay, from the lowest: compounds 1, 2 and 3 (each within the scatter of the next). At a limit, above all of these: compound 4.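

In this assay compound 4 is reported only as a limit of the assay, not as a number: the limit of > 50000 nM in this assay, at which 1 of the 4 values shown sits. The amine nitrogen had shown no response to the one earlier exchange, a 1.3-fold higher number from compound 2 to compound 3 (0.12 log units; within the scatter), but it is not indifferent to every group, as phenyl in place of isobutyl gives an at least 37-fold higher number from compound 3 to compound 4 (1.57 log units; beyond the scatter) and anilino in place of pyrrolidin-1-yl gives an at least 50-fold higher number from compound 2 to compound 4 (1.70 log units; beyond the scatter). Among these compounds, this is the first change at this position that lies beyond the scatter, and it comes with an aromatic ring placed directly on the nitrogen.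

The compounds shown do not separate the presence of the ring from its direct attachment to the nitrogen. A benzylamino or cyclohexylamino group on the same chain would bear on that question.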